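Sulfonamide heteroaryl exchange across two related cores

This account rests on a few compounds, and the source may have more. Where it says the series, first, only, none or still open, it means among the compounds named here.

Measured so far:
Compound 1, `N#Cc1c(-c2ccccc2)cn(-c2ccc(S(=O)(=O)Nc3nccs3)cc2)c1NC(=O)CCC(=O)O`, gives 9120 nM in a functional assay on MCF7 cells (Homo sapiens) for inhibition, read by sulforhodamine B assay, with a stated time of 24 h; on this read-out higher numbers stand for weaker inhibition and lower numbers for stronger inhibition.
Compound 2, `N#Cc1c(-c2ccccc2)cn(-c2ccc(S(=O)(=O)Nc3ccccn3)cc2)c1NC(=O)CCC(=O)O`, gives 8320 nM in this assay.
Compound 3, `Cc1nc2c(c(-c3ccccc3)cn2-c2ccc(S(=O)(=O)Nc3nccs3)cc2)c(=O)[nH]1`, gives 5800 nM in this assay.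

Compound 1 and compound 2 share one core and differ only by pyridin-2-yl in place of 1,3-thiazol-2-yl on a sulfonamide nitrogen. That change gives a 1.1-fold lower number from compound 1 to compound 2 (0.04 log units; within the scatter). Compound 3 carries a different core; how it differs from compound 1 is not broken down here, and the two values, compound 1 at 9120 nM and compound 3 at 5800 nM, lie within the scatter of each other, so no order between them is claimed.

Compound 4, `Cc1nc2c(c(-c3ccccc3)cn2-c2ccc(S(=O)(=O)Nc3ccccn3)cc2)c(=O)[nH]1`, is not yet measured. It stands to compound 3 as compound 2 stands to compound 1: pyridin-2-yl in place of 1,3-thiazol-2-yl on a sulfonamide nitrogen, at the same place, so this is the same change made on the second core. The expectation for the step rests on compound 1 and compound 2, whose step is a 1.1-fold lower number from compound 1 to compound 2 (0.04 log units; within the scatter), applied to compound 3 at 5800 nM; the step from compound 3 to compound 4 is expected to be a 1.1-fold lower number from compound 3 to compound 4 (0.04 log units; within the scatter). Compound 4 is therefore estimated at 5300 nM in this assay, with a range from 2500 nM to 11000 nM expected.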

Compound 4, half-maximal inhibitory concentration: 5100 nM
Estimate against measurement, compound 4: 1.0-fold (0.02 log units) above, within the range that was stated.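

In this assay, pyridin-2-yl in place of 1,3-thiazol-2-yl on a sulfonamide nitrogen gives a 1.1-fold lower number from compound 3 to compound 4 (0.06 log units; within the scatter) on the second core, and the exchange reads alike on both cores: the same change on two cores in this assay, a 1.1-fold lower number (0.04 log units; within the scatter) from compound 1 to compound 2 and a 1.1-fold lower number (0.06 log units; within the scatter) from compound 3 to compound 4, 1.0-fold (0.02 log units) apart, within the scatter of two such steps. Both steps lie within the scatter, so what carries from one core to the other is the absence of a measurable step on this read-out, not a gain that can be transferred. This does not show that the change would behave alike on a third core or in another assay, and two steps this small cannot reveal a dependence on the core that would appear only with a larger effect.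

Still open, on these data alone, is whether a different group on the sulfonamide nitrogen, such as pyrimidin-2-yl, methyl or a bare hydrogen, would give a step beyond the scatter on either core. Also open, as far as these compounds go, is whether a basic amine on a longer chain at that nitrogen would separate the two cores.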